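A Chlorophenyl Swap Carried onto a Hydroxybenzimidazole Core

The source may report more compounds than this note shows. Statements on the series, on what has been measured and on what is new or still open speak of the compounds shown alone.

Compound 1 `Cc1ccc2[nH]c(-c3ccc(-c4ccc(-c5ccc(N(C)C)cc5)cc4)cc3)nc2c1` and compound 2 `Cc1ccc2[nH]c(-c3ccc(-c4ccc(-c5cccc(Cl)c5)cc4)cc3)nc2c1` differ in one place: 3-chlorophenyl in place of 4-(dimethylamino)phenyl on an aromatic carbon. In a functional assay on MCF7 cells (Homo sapiens) for inhibition, read by sulforhodamine B assay (on this read-out higher numbers stand for weaker inhibition of growth and lower numbers for stronger inhibition of growth), compound 1 gives 3130 nM, while compound 2 gives 1210 nM, so the change produced a 2.6-fold lower number from compound 1 to compound 2 (0.41 log units; beyond the scatter). Compound 3 `CN(C)c1ccc(-c2ccc(-c3ccc(-c4nc5c(O)cccc5[nH]4)cc3)cc2)cc1` carries a different core, and the difference is 4-hydroxy-1H-benzimidazol-2-yl in place of 5-methyl-1H-benzimidazol-2-yl on an aromatic carbon. In this assay compound 3 gives 2310 nM, which amounts to a 1.4-fold lower number from compound 1 to compound 3 (0.13 log units; within the scatter).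

Compound 4 `Oc1cccc2[nH]c(-c3ccc(-c4ccc(-c5cccc(Cl)c5)cc4)cc3)nc12` has not been measured. It stands to compound 3 as compound 2 stands to compound 1: 3-chlorophenyl in place of 4-(dimethylamino)phenyl on an aromatic carbon. The place of this change reads the same in both pairs, so it is the same change, occurring twice among these four compounds.

Compound 4 is expected to show a 2.6-fold lower number from compound 3 to compound 4 (0.41 log units; beyond the scatter), because the same change gave a 2.6-fold lower number from compound 1 to compound 2 (0.41 log units; beyond the scatter) and because the swap of cores gave only a 1.4-fold lower number from compound 1 to compound 3 (0.13 log units; within the scatter). Compound 4 is therefore estimated at 900 nM, with a likely range from 400 nM to 2000 nM.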

Compound 4, concentration for 50% growth inhibition: 3420 nM
Estimate against measurement, compound 4: 3.8-fold (0.58 log units) below, and the stated range ends below it.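

With the 4-hydroxy-1H-benzimidazol-2-yl group in place of the 5-methyl-1H-benzimidazol-2-yl group, putting 3-chlorophenyl in place of 4-(dimethylamino)phenyl gave a 1.5-fold higher number from compound 3 to compound 4 (0.17 log units; within the scatter) in this assay, so the gain seen on the other core did not reappear. Set side by side, the two steps show that this change cannot be carried from one core to the other in this series with its size unchanged: the same change on two cores in this assay, a 2.6-fold lower number (0.41 log units; beyond the scatter) from compound 1 to compound 2 and a 1.5-fold higher number (0.17 log units; within the scatter) from compound 3 to compound 4, 3.8-fold (0.58 log units) apart, beyond the scatter of two such steps This rests on a single pair of steps on two cores, so it does not show what sets the two cores apart, nor whether other replacements would behave in the same way.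

The compounds shown leave open whether a carboxylic acid or a primary amine on the terminal ring would also differ in its effect between the two cores. They also leave open how a core carrying a methoxy group instead of the hydroxyl would respond to the same change.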